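A few compounds are considered here, and "the series" means these few. Any claim that something is new, unique, unknown or untested is made for them only; others in the source may bear on it.

Values so far in a functional assay on LoVo cells (Homo sapiens) for inhibition, read by MTT assay, with a stated time of 24 h (a lower number here means a stronger inhibitor, a higher number a weaker inhibitor), for the series
- compound 1 `CC1(C)[C@H]2CC[C@]1(C)N(Cc1cn(-c3ccccc3F)nn1)C(=O)C2` gives 40 nM
- compound 2 `CC1(C)[C@H]2CC[C@]1(C)N(Cc1cn(-c3cccc(Cl)c3)nn1)C(=O)C2` gives 70 nM
- compound 3 `CC1(C)[C@H]2CC[C@]1(C)N(Cc1cn(-c3ccc(O)cc3)nn1)C(=O)C2` gives 410 nM

Compound 2 cannot be separated from compound 1 on these numbers, with a 1.8-fold higher number from compound 1 to compound 2 (0.24 log units; within the scatter) as the whole gap. It stands clear of compound 3, with a 5.9-fold higher number from compound 2 to compound 3 (0.77 log units; beyond the scatter) as the gap.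

Compound 4 `Cc1ccccc1-n1cc(CN2C(=O)C[C@@H]3CC[C@@]2(C)C3(C)C)nn1` is not yet measured. It differs from compound 2 in one group, with 2-methylphenyl in place of 3-chlorophenyl on an aromatic nitrogen of a five-membered aromatic ring with 3 nitrogen. The counted difference is 2-methylphenyl in place of 3-chlorophenyl on an aromatic nitrogen and the rest of the structure is shared.

The nearest evidence is the exchange of 2-fluorophenyl for 3-chlorophenyl, which gave a 1.8-fold higher number from compound 1 to compound 2 (0.24 log units; within the scatter) and so no resolved change. The two steps beyond the scatter both bring in 4-hydroxyphenyl, a 10-fold higher number from compound 1 to compound 3 (1.01 log units; beyond the scatter) and a 5.9-fold higher number from compound 2 to compound 3 (0.77 log units; beyond the scatter), and compound 4 does not carry that group. Within the data shown here, no measured compound carries 2-methylphenyl, so the data give no direct reading of it.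

No shift beyond the scatter is expected in this assay in either direction, and the expected change is a 1.3-fold lower number from compound 2 to compound 4 (0.10 log units; within the scatter) with no weight placed on its sign. For compound 4 the estimated value is 55 nM with an expected range from 20 nM to 150 nM in this assay.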

Compound 4, half-maximal inhibitory concentration: 80 nM
The estimate for compound 4 lay 1.5-fold (0.16 log units) below the measured number, within the range that was stated.
By their numbers in this assay, from the lowest: compounds 1, 2 and 4 (each within the scatter of the next); then compound 3.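

In this assay the exchange of 3-chlorophenyl for 2-methylphenyl on the aromatic nitrogen gives a 1.1-fold higher number from compound 2 to compound 4 (0.06 log units; within the scatter) and no resolved change, and methyl in place of fluoro on an aromatic carbon gives a 2.0-fold higher number from compound 1 to compound 4 (0.30 log units; within the scatter) and likewise no resolved change. Among these compounds, then, a halogen on the aromatic ring is not needed to keep the number level with compound 1 and compound 2, since the 2-methylphenyl group holds carbon only and the same count of heavy atoms as 3-chlorophenyl. Compound 3 alone stands apart, with a 5.1-fold lower number from compound 3 to compound 4 (0.71 log units; beyond the scatter) as its gap, and no supporting data explain why the three other groups cannot be separated here.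

The shown compounds do not separate the hydroxyl group itself from where it sits, as the only hydroxyl compound carries it on 4-hydroxyphenyl while the three others carry different groups at different ring places. Also open, on these data alone, is whether the aromatic ring tolerates a methoxy group, an amine or a carboxylic acid, and whether a plain unsubstituted phenyl or a longer chain in place of the aromatic ring keeps the number.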